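This account rests on a few compounds, and the source may have more. Where it says the series, first, only, none or still open, it means among the compounds named here.

Measured compounds:
compound 1, `CCCCCCNc1nc(SCC)nc2ncccc12`, 22500 nM
compound 2, `CCCCCCNc1nc(SC(C)C)nc2ncccc12`, 20200 nM
compound 3, `CCCCNc1nc(SCCCC)nc2ncccc12`, 13600 nM

In a functional assay on HT-29 cells (Homo sapiens) for cytotoxicity, read by neutral red uptake, with a stated time of 72 h (on this read-out higher numbers stand for weaker inhibition and lower numbers for stronger inhibition), compound 1 gives 22500 nM and compound 2 gives 20200 nM. The change between them is methyl in place of hydrogen on a saturated chain carbon bound to a saturated chain carbon and a sulfur, and it makes a 1.1-fold lower number from compound 1 to compound 2 (0.05 log units; within the scatter). Compound 3 gives 13600 nM in this assay; the difference between the core of compound 3 and the core of compound 1 is not broken down here.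

Compound 4, `CCCCCNc1nc(SCCCC)nc2ncccc12`, is not yet measured. It differs from compound 3 by methyl in place of hydrogen on a saturated chain carbon, four bonds along the chain from a nitrogen on an aromatic ring. This is the same kind of change as that from compound 1 to compound 2, not the same: there the place was on a saturated chain carbon bound to a saturated chain carbon and a sulfur, here it is on a saturated chain carbon, four bonds along the chain from a nitrogen on an aromatic ring. Because a 1.1-fold lower number from compound 1 to compound 2 (0.05 log units; within the scatter) stayed within the scatter, the expected step is a 1.1-fold lower number from compound 3 to compound 4 (0.05 log units; within the scatter), small. Compound 4 is expected at 12000 nM in this assay, between 6000 nM and 25000 nM.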

Compound 4, half-maximal inhibitory concentration: 12600 nM
Estimate against measurement, compound 4: 1.1-fold (0.02 log units) below; low and high end bracket the measured number.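

In this assay, methyl in place of hydrogen gives a 1.1-fold lower number from compound 3 to compound 4 (0.03 log units; within the scatter), and the two cores do not differ in this step: the same change on two cores in this assay, a 1.1-fold lower number (0.05 log units; within the scatter) from compound 1 to compound 2 and a 1.1-fold lower number (0.03 log units; within the scatter) from compound 3 to compound 4, 1.0-fold (0.01 log units) apart, within the scatter of two such steps

The change therefore carries from one core to the other as a step within the scatter, although it sits at a different place on each: on the sulfur chain in one pair, and on the chain on the nitrogen in the other. Two such pairs show no detectable effect of this methyl and give no direction for it, and they do not show that the step would stay this small on other cores or at other places.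

The compounds shown carry only plain saturated chains. Still open, as far as these compounds go, is how a much longer chain, or an amine or a carboxylic acid on either chain, would read in this assay.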